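A few compounds are considered here, and "the series" means these few. Any claim that something is new, unique, unknown or untested is made for them only; others in the source may bear on it.

Measured so far in a functional assay on HEK293 cells for antagonist activity at thromboxane A2 receptor (Homo sapiens), read by fluorescence and calcium flux; a higher number here means a weaker inhibitor, a lower number a stronger inhibitor: compound 1 `Cc1ccccc1Oc1ccc(C#N)cc1S(=O)(=O)NC(=O)NC(C)C` gives 8680 nM; compound 2 `Cc1ccccc1Oc1ccc(C#N)cc1S(=O)(=O)NC(=O)NC(C)(C)C` gives 3690 nM.

Compound 2 holds the lower of the two numbers; compound 1 is its nearest neighbour, separated by a 2.4-fold lower number from compound 1 to compound 2 (0.37 log units; beyond the scatter). Compound 3 `CCCCCNC(=O)NS(=O)(=O)c1cc(C#N)ccc1Oc1ccccc1C` differs from compound 2 by pentyl in place of tert-butyl on an amide-type nitrogen. Among the measured compounds shown here, only that one measured step bears on the change, and it concerns a different alteration at the same nitrogen, so it guides the expectation only loosely. In this assay a modest step is expected at most: a 1.5-fold higher number from compound 2 to compound 3 (0.17 log units; within the scatter). Compound 3 is expected to give about 5500 nM, within 2200 nM to 14000 nM.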

Compound 3, half-maximal inhibitory concentration: 2240 nM
Estimate against measurement, compound 3: 2.5-fold (0.39 log units) above; the range from low to high includes it.
By their numbers in this assay, from the lowest: compounds 3 and 2 (each within the scatter of the next); then compound 1.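

Pentyl and tert-butyl on the amide-type nitrogen cannot be told apart here (a 1.6-fold lower number from compound 2 to compound 3 (0.22 log units; within the scatter)), so branching at the carbon on this nitrogen is not needed to reach the level of compound 2. Pentyl also separates from the isopropyl of compound 1 (a 3.9-fold lower number from compound 1 to compound 3 (0.59 log units; beyond the scatter)), the largest step in the series so far. No available evidence accounts for these steps.

Open, from the compounds shown here alone, is whether a longer chain such as octyl, or a cyclohexyl ring, moves the number further. Also open, going by these compounds, is how a chain ending in an amine or a carboxylic acid would compare with pentyl.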